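Piperidine substituents on a basic side chain, third variant

The source may hold more compounds than are shown below. What is called first, only, known or untested is meant among the compounds shown, and "the series" means these compounds.

Compound 1 `COc1cc2c(Nc3ccc(C#N)cc3)ncnc2cc1OCCCN1CCC(C)CC1` gives 43100 nM in a functional assay on MCF7 cells (Homo sapiens) for antiproliferative activity, read by MTT assay, with a stated time of 72 h; on this read-out higher numbers stand for weaker inhibition and lower numbers for stronger inhibition. Compound 2 `COc1cc2c(Nc3ccc(C#N)cc3)ncnc2cc1OCCCN1CCCCC1CCO` is reported in this assay only as the limit > 100000 nM, so for compound 2 only a limit and no number is known (the limit of > 100000 nM in this assay, at which 1 of the 2 values shown sits). For the measured compounds named here, the one measured step, an at least 2.3-fold higher number from compound 1 to compound 2 (0.36 log units; beyond the scatter), is the sole guide for the change to compound 3 `COc1cc2c(Nc3ccc(C#N)cc3)ncnc2cc1OCCCN1CCC(c2ccccc2)CC1`, which differs from compound 2 in that (4-phenylpiperidin-1-yl in place of 2-(2-hydroxyethyl)piperidin-1-yl on a saturated chain carbon, three bonds along the chain from an oxygen on an aromatic ring). Going by the values given here, that step ran toward weaker inhibition when the 2-(2-hydroxyethyl)piperidin-1-yl group entered; compound 3 removes that group again and brings in 4-phenylpiperidin-1-yl, which has no measured precedent here, so the direction is uncertain and compound 2 offers only a lower bound. Compound 3 is therefore expected to return roughly to the region of compound 1, with the estimated step of an at least 3.3-fold lower number from compound 2 to compound 3 (0.52 log units; beyond the scatter), and its estimated value in this assay is 30000 nM, within 6000 nM to 100000 nM; a further limit-only result remains a real possibility.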

Compound 3, half-maximal inhibitory concentration: 9800 nM
Compound 3: middle estimate off by 3.1-fold (0.49 log units), on the high side; measured number inside the range.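

In this assay, for the compounds shown here, phenyl in place of methyl on a saturated ring carbon gives a 4.4-fold lower number from compound 1 to compound 3 (0.64 log units; beyond the scatter), so compound 3 is the first piperidine variant here to move the number down from that of compound 1 rather than up. Exchanging 2-(2-hydroxyethyl)piperidin-1-yl for 4-phenylpiperidin-1-yl gives an at least 10-fold lower number from compound 2 to compound 3 (1.00 log units; beyond the scatter), which shows that the piperidine substituent at this place spans a wider range than the earlier step alone revealed. That step remains a bound, as compound 2 is held only as a limit of the assay: the limit of > 100000 nM in this assay, at which 1 of the 3 values shown sits.

Going by these compounds, whether the lower number depends on the aromatic ring itself stays open, and a cyclohexyl or benzyl group on the same ring carbon would separate these readings. Also open, on these data alone, is how a morpholine or piperazine in place of the piperidine, or a longer chain, would read.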